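The source may report more compounds than this note shows. Statements on the series, on what has been measured and on what is new or still open speak of the compounds shown alone.

Compound 1 `CNC(=O)N1CCCc2ccc(NC(=O)c3ccc(-c4ccccc4)cc3)cc21`, compound 2 `CNC(=O)N1CCCc2ccc(NC(=O)c3ccc(-c4ccn(C)n4)cc3)cc21` and compound 3 `CNC(=O)N1CCCc2ccc(NC(=O)c3ccc(-c4cnn(C)c4)cc3)cc21` share one core and differ only in the group attached on an aromatic carbon of the outer ring. In a functional assay on MV4-11 cells (Homo sapiens) for antiproliferative activity, with a stated time of 6 days, tested at 1.56 uM (a higher number here means a stronger effect of the compound at the concentration tested, a lower number a weaker effect), compound 1 gives 19.7%, compound 2 gives 72.2% and compound 3 gives 77.4%. Compound 3 has the highest of the three numbers, but its nearest neighbour is compound 2, and the change a number 5.2 percentage points higher from compound 2 to compound 3 (within the scatter) lies within the scatter, so the two cannot be ordered. Against compound 1 both stand clearly apart: a number 52.5 percentage points higher from compound 1 to compound 2 (beyond the scatter) and a number 57.7 percentage points higher from compound 1 to compound 3 (beyond the scatter).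

Compound 4 `CNC(=O)N1CCCc2ccc(NC(=O)c3ccc(-c4ccn(C(C)=O)n4)cc3)cc21` is not yet measured. It differs from compound 3 in this way: 1-acetyl-1H-pyrazol-3-yl in place of 1-methyl-1H-pyrazol-4-yl on an aromatic carbon. For the measured compounds named here, two measured steps bear on it. The step of a number 52.5 percentage points higher from compound 1 to compound 2 (beyond the scatter) shows that a 1-methyl-1H-pyrazol-3-yl group gives a large rise over phenyl, and a number 5.2 percentage points higher from compound 2 to compound 3 (within the scatter) shows that the two attachment patterns of the methylpyrazole are within the scatter of each other. Nothing measured speaks to an acetyl in place of a methyl on the pyrazole nitrogen. Compound 4 is therefore expected near the pyrazole pair, with a modest expected drop of a number 15.4 percentage points lower from compound 3 to compound 4 (beyond the scatter) in this assay to allow for the untested acetyl. Compound 4 is estimated at 62%, within 35% to 82%.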

Compound 4, a percentage reported as inhibition, at one concentration (the size of the read-out at that concentration, not a potency): 35.8%
For compound 4 the middle estimate is 26.2 percentage points above the measured one; the measured number falls inside the stated range.
By their numbers in this assay, from the lowest: compound 1; then compound 4; then compounds 2 and 3 (each within the scatter of the next).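

In this assay, for the compounds shown here, the group on the pyrazole nitrogen turns out to matter: acetyl in place of methyl gives a number 36.4 percentage points lower from compound 2 to compound 4 (beyond the scatter), whereas the earlier compounds showed only that the two methylpyrazole attachment patterns could not be ordered. The replacement of 1-methyl-1H-pyrazol-4-yl is also large, at a number 41.6 percentage points lower from compound 3 to compound 4 (beyond the scatter), so a pyrazole at this position, para to a large group, does not by itself secure the high numbers of the methylpyrazoles, although part of the rise over phenyl remains, with a number 16.1 percentage points higher from compound 1 to compound 4 (beyond the scatter). No measurement at hand accounts for this drop.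

The compounds shown leave open whether the drop belongs to the acetyl group itself or would also appear with another group on that nitrogen, such as an ethyl group, a longer chain, a chain ending in an amine, or simply hydrogen. They also leave open whether a 1-acetyl-1H-pyrazol-4-yl group would give a number like that of compound 4 or stay closer to its methyl counterpart, compound 3.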